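Replacing a Protected Chain with a Carboxamide-Bearing Ring

This account rests on a few compounds, and the source may have more. Where it says the series, first, only, none or still open, it means among the compounds named here.

Of the compounds shown here, two sharing one core have been measured in an assay on HEK293 cells for displacement of a labelled ligand from NPC1-like intracellular cholesterol transporter 1 (Homo sapiens); a higher number here means a weaker inhibitor, a lower number a stronger inhibitor. Compound 1 `O=C(CN1CN(c2ccccc2)C2(CCN(C(=O)c3ccc(C4CCCCC4)cc3)CC2)C1=O)N1CCCCC1` carries a piperidin-1-yl group on the carbonyl carbon of its side chain and gives 1100 nM. Compound 2 `CC(C)(C)OC(=O)NCCNC(=O)CN1CN(c2ccccc2)C2(CCN(C(=O)c3ccc(C4CCCCC4)cc3)CC2)C1=O` bears a (2-((tert-butoxycarbonyl)amino)ethyl)amino group there instead and gives 5500 nM, the highest number of the two. The step of a 5.0-fold higher number from compound 1 to compound 2 (0.70 log units; beyond the scatter) shows that opening the ring into this protected chain weakened binding by a modest amount.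

Compound 3 `NC(=O)C1CCCN(C(=O)CN2CN(c3ccccc3)C3(CCN(C(=O)c4ccc(C5CCCCC5)cc4)CC3)C2=O)C1` is the next compound to be measured. The change from compound 2 is 3-carbamoylpiperidin-1-yl in place of (2-((tert-butoxycarbonyl)amino)ethyl)amino on a carbonyl carbon. This brings back a six-membered ring on the carbonyl carbon, close to what compound 1 has, while adding a carbamoyl group on that ring. Going by the values given here, only the step of a 5.0-fold higher number from compound 1 to compound 2 (0.70 log units; beyond the scatter) bears on this move, and it ran in the opposite direction. A return toward the number of compound 1 is therefore expected, though the added group leaves room for uncertainty. The expected step is a 2.8-fold lower number from compound 2 to compound 3 (0.44 log units; beyond the scatter). Compound 3 is estimated at 2000 nM in this assay, within a range of 700 nM to 6000 nM.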

Compound 3, half-maximal inhibitory concentration: 3100 nM
The estimate for compound 3 lay 1.6-fold (0.19 log units) below the measured number; the range from low to high includes it.
By their numbers in this assay, from the lowest: compound 1; then compounds 3 and 2 (each within the scatter of the next).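

Going by these compounds alone, compound 3 isolates a single change for the first time: a 2.8-fold higher number from compound 1 to compound 3 (0.45 log units; beyond the scatter) shows that, on the piperidine ring attached to this carbonyl carbon, a carbamoyl group is not tolerated as well as hydrogen in this assay. Restoring a six-membered ring at this position is therefore not enough on its own to recover the number of compound 1, and among these three compounds the unsubstituted piperidin-1-yl group still gives the lowest number. At the same time, a 1.8-fold lower number from compound 2 to compound 3 (0.25 log units; within the scatter) leaves the ring bearing the carbamoyl group and the open protected chain indistinguishable in this measurement, even though the two groups differ in ring content and in their counts of hydrogen-bond donors and acceptors; no available evidence accounts for the effect of the carbamoyl group.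

The compounds shown do not reveal whether the step from compound 1 to compound 3 is particular to carbamoyl or would also appear with another group on the same ring, such as a methyl, a hydroxyl, an amine or a carboxylic acid. They also leave open how a free aminoethyl chain, without the tert-butoxycarbonyl group, would compare with the protected chain of compound 2.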